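The compounds below may be only part of what the source reports. "The series", "measured", "known", "first", "only" and "open" are said of these compounds alone.

Compound 1 `Cc1[nH][n+](C)c(C)c1C(=O)Nc1ccc2nc(NC(=O)C3CCCCC3)sc2c1` gives 0.012 ug/mL in a functional assay on WI-38 VA13 cells (Homo sapiens) for cytotoxicity; a higher number here means that more compound is needed for the effect, a lower number that less compound is needed. In this assay compound 2 `Cc1cc(C(=O)Nc2ccc3nc(NC(=O)C4CCCCC4)sc3c2)c(C)n1C` gives only a limit, > 6.2 ug/mL. For the measured compounds named here, the one measured step, an at least 510-fold higher number from compound 1 to compound 2 (2.71 log units; beyond the scatter), ends at the limit of > 6.2 ug/mL in this assay, at which 1 of the 3 values shown sits. In this assay compound 3 `O=C(O)CCC(=O)Nc1nc2ccc(NC(=O)c3c(Cl)cccc3Cl)cc2s1` also gives only a limit, > 6.6 ug/mL, so its value is a bound, not a number, standing at the limit of > 6.6 ug/mL in this assay, at which 1 of the 3 values shown sits. Compound 4 `COc1cccc(Nc2nc3ccc(NC(=O)c4c(Cl)cccc4Cl)cc3s2)c1` differs from compound 3 by 3-methoxyphenyl in place of (2-carboxyethyl)carbonyl on a nitrogen on an aromatic ring. Going by the values given here, no measured step covers this change, since the single step of an at least 510-fold higher number from compound 1 to compound 2 (2.71 log units; beyond the scatter) alters a different part of the shared core, and no direction can be taken from it. Compound 4 is therefore expected near 3 ug/mL, within 0.3 ug/mL to 20 ug/mL. The expected step of an at least 2.2-fold lower number from compound 3 to compound 4 (0.34 log units; beyond the scatter) rests only on a limit and is uncertain.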

Compound 4, half-maximal effective concentration: > 7.2 ug/mL
Compound 4: no number, only a limit; the forecaster's own chance of this, stated with the estimate: 40%; middle value at least 2.4-fold (0.38 log units) away from the limit.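

For the compounds shown here, compound 3 and compound 4 both give only a limit in this assay, so no step between them can be read. The compounds shown leave open whether 3-methoxyphenyl in place of (2-carboxyethyl)carbonyl changes the result in this assay at all.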